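A few compounds are considered here, and "the series" means these few. Any claim that something is new, unique, unknown or untested is made for them only; others in the source may bear on it.

Two measured compounds set the scene. Within the data shown here, compound 1 `Cn1ccc(S(=O)(=O)c2ccc3c(c2)CCC[C@H]3CN)c1` is the first; in an assay on isolated protein for displacement of a labelled ligand from 5-hydroxytryptamine receptor 6 (Homo sapiens) (on this read-out higher numbers stand for weaker inhibition and lower numbers for stronger inhibition), compound 1 gives 7.94 nM. Compound 2 `O=S(=O)(c1cccc(F)c1)c1ccc2c(c1)CCC[C@H]2CN1CCCS1(=O)=O` shares the core of compound 1 but differs in its side groups; in this assay compound 2 gives 31.6 nM. Of the two numbers, compound 2 stands at the higher one, and its distance from compound 1 lies beyond the usual scatter of repeated measurements. Compound 3 `N=C(N)NC(=O)C[C@@H]1CCCc2cc(S(=O)(=O)c3cccc(F)c3)ccc21` is the next step from compound 2: a group of 6 heavy atoms (2 carbon, 3 nitrogen, 1 oxygen; no ring) in place of a group of 7 heavy atoms (3 carbon, 1 nitrogen, 2 oxygen, 1 sulfur; one five-membered non-aromatic ring with 2 hetero atoms), on a saturated chain carbon bound to a saturated ring carbon. Among the measured compounds shown here, no pair of measured compounds shows this kind of change, so no measured step can guide the expectation; only the gap between compound 1 at 7.94 nM and compound 2 at 31.6 nM hints at how much the group on this chain matters. The step of a 1.3-fold lower number from compound 2 to compound 3 (0.10 log units; within the scatter) is expected to be small, not clearly beyond the scatter in either direction. Compound 3 is therefore expected to give 25 nM, within a range from 6 nM to 100 nM.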

Compound 3, inhibition constant: 0.631 nM
Estimate against measurement, compound 3: 40-fold (1.60 log units) above, and the stated range ends above it.
By their numbers in this assay, from the lowest: compound 3; then compound 1; then compound 2.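

In this assay, the group on a saturated chain carbon bound to a saturated ring carbon turns out to have a strong hold on the result: this one exchange gives a 50-fold lower number from compound 2 to compound 3 (1.70 log units; beyond the scatter) and so moves the number far beyond the usual scatter. The entering group has no ring and 3 hydrogen-bond donors, while the leaving group has a five-membered non-aromatic ring and 0 donors, and a single step cannot separate these differences. No measurement shown here accounts for the size of the step.

From the compounds shown here alone, it remains open whether a carboxylic acid or a plain primary amide in this place would give a similarly low number. Going by these compounds, it is also open whether the same entering group would act in this way alongside the other side group of compound 1.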